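Hydrazone aryl replacement on the triazolopyrimidine series

The source may report more compounds than this note shows. Statements on the series, on what has been measured and on what is new or still open speak of the compounds shown alone.

Measured so far:
- compound 1 `CCCSc1nc(N/N=C/c2cccnc2)c2nnn(Cc3ccccc3)c2n1` — 58700 nM
- compound 2 `C#CCSc1nc(N/N=C(\C)c2ccccc2O)c2nnn(Cc3ccccc3)c2n1` — 11300 nM
- compound 3 `C/C(=N\Nc1nc(SCc2ccccc2)nc2c1nnn2Cc1ccccc1)c1ccccc1O` — 950 nM

In a functional assay on MCF7 cells (Homo sapiens) for antiproliferative activity, read by MTT assay, with a stated time of 72 h (on this read-out lower numbers stand for stronger inhibition and higher numbers for weaker inhibition), compound 1 gives the highest of the three numbers; compound 2 is nearer to it and compound 3 furthest. Going by the values given here, the only single-point step recorded is a 12-fold lower number from compound 2 to compound 3 (1.08 log units; beyond the scatter), which concerns the sulfur substituent and not the hydrazone end. Compound 4 `CCCSc1nc(N/N=C/c2c(O)ccc3ccccc23)c2nnn(Cc3ccccc3)c2n1` differs from compound 1 by 2-hydroxynaphthalen-1-yl in place of pyridin-3-yl on a carbon with a double bond to nitrogen. Among the compounds with values here, no measured pair isolates this change; compounds 2 and 3 carry a hydroxyaryl at the hydrazone carbon yet also differ from compound 1 elsewhere, so their values only hint that compound 4 may give a lower number. Compound 4 is therefore expected at 15000 nM (range 4000 nM to 55000 nM), an estimated step of a 3.9-fold lower number from compound 1 to compound 4 (0.59 log units; beyond the scatter).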

Compound 4, half-maximal inhibitory concentration: 6400 nM
Beside the measured number, compound 4's estimate is 2.3-fold (0.37 log units) above it, and the stated range covers the measured number.
By their numbers in this assay, from the lowest: compound 3; then compounds 4 and 2 (each within the scatter of the next); then compound 1.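

In this assay, the hydrazone end now has its first reading in a single place: 2-hydroxynaphthalen-1-yl in place of pyridin-3-yl gives a 9.2-fold lower number from compound 1 to compound 4 (0.96 log units; beyond the scatter). The change alters the aromatic rings and adds a hydroxyl together, so this pair cannot divide the step between them. No evidence on hand gives a cause for the step.

Still open, going by these compounds, is whether a plain naphthalen-1-yl, or an amine in place of the hydroxyl, would keep the step. Also open, on these data alone, is how this group behaves with a sulfur substituent other than the propyl chain.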